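The source may report more compounds than this note shows. Statements on the series, on what has been measured and on what is new or still open speak of the compounds shown alone.

Working notes on the series. Compound 1 `O=C1c2ccccc2CCCN1CCN1CCC(Oc2ccccc2)CC1` carries a phenoxy group on the piperidine, and in an assay on isolated protein for binding affinity to 5-hydroxytryptamine receptor 7 (Homo sapiens) (a lower number here means a stronger inhibitor, a higher number a weaker inhibitor), compound 1 gives 20.4 nM. Compound 2 `O=C1c2ccccc2CCCN1CCN1CCC(Oc2ccc(F)cc2)CC1` differs from compound 1 by fluoro in place of hydrogen on an aromatic carbon; in this assay compound 2 gives 4.47 nM, a step of a 4.6-fold lower number from compound 1 to compound 2 (0.66 log units; beyond the scatter). Compound 3 `O=C1c2ccccc2CCCN1CCN1CCC(n2nnc3ccccc32)CC1` replaces the phenoxy group, and in this assay compound 3 gives 14.1 nM; the step is a 1.4-fold lower number from compound 1 to compound 3 (0.16 log units; within the scatter), and against compound 2 it is a 3.2-fold higher number from compound 2 to compound 3 (0.50 log units; beyond the scatter).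

Compound 4 `O=C1c2ccccc2CCCN1CCN1CCC(n2nnc3cc(F)ccc32)CC1` is not yet measured. It differs from compound 3 by fluoro in place of hydrogen on an aromatic carbon, the same kind of change as fluoro in place of hydrogen on an aromatic carbon, though the place is not the same: in compound 2 the fluoro sits para to a large group, in compound 4 it sits on a ring that is part of a fused or bridged system of two rings, meta to a fused ring and para to a fused ring. The two cores differ by a group of 9 heavy atoms (6 carbon, 3 nitrogen; one five-membered aromatic ring with 3 hetero atoms, one six-membered aromatic ring of carbon only) in place of a group of 7 heavy atoms (6 carbon, 1 oxygen; one six-membered aromatic ring of carbon only), on a saturated ring carbon. Because the step of a 4.6-fold lower number from compound 1 to compound 2 (0.66 log units; beyond the scatter) was made at a different place, a smaller step is expected here, a 2.0-fold lower number from compound 3 to compound 4 (0.30 log units; within the scatter). For compound 4 in this assay the estimate is 7 nM, expected between 3 nM and 18 nM.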

Compound 4, inhibition constant: 2.04 nM
Beside the measured number, compound 4's estimate is 3.4-fold (0.54 log units) above it; the whole stated range lies above it.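

In this assay, fluoro in place of hydrogen on an aromatic carbon gives a 6.9-fold lower number from compound 3 to compound 4 (0.84 log units; beyond the scatter), and this step matches the one on the phenoxy core: the same change on two cores in this assay, a 4.6-fold lower number (0.66 log units; beyond the scatter) from compound 1 to compound 2 and a 6.9-fold lower number (0.84 log units; beyond the scatter) from compound 3 to compound 4, 1.5-fold (0.18 log units) apart, within the scatter of two such steps. With fluoro on both cores, the replacement of the phenoxy group gives a 2.2-fold lower number from compound 2 to compound 4 (0.34 log units; beyond the scatter), and the two changes together give a 10-fold lower number from compound 1 to compound 4 (1.00 log units; beyond the scatter). Going by these compounds alone, this is only two pairs, with the fluoro at a different place on each core, so the agreement shows that the step carried over in these two cases; it does not show that fluoro at any other place would give a step of this size, and it gives no cause for the step.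

As far as these compounds go, it remains open whether chloro, methoxy or nitrile at these same places would give a step of similar size, or whether fluoro at another carbon of either aromatic ring would. Also open, from the compounds shown here alone, is whether the step holds on a core with a longer chain linking the piperidine to the amide nitrogen.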